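The source may hold more compounds than are shown below. What is called first, only, known or untested is meant among the compounds shown, and "the series" means these compounds.

Compound 1 `O=S(=O)(/C=C/c1ccccc1)Cc1ccc(Nc2ncnc3ccccc23)cc1`: > 100000 nM (a limit of the assay)
Compound 2 `O=S(=O)(/C=C/c1ccc(F)cc1)Cc1ccc(Nc2ncnc3ccccc23)cc1`: 13000 nM

Both values come from a functional assay on NCI-H520 cells (Homo sapiens); on this read-out higher numbers stand for weaker inhibition of growth and lower numbers for stronger inhibition of growth. Among the compounds with values here, compound 2 at 13000 nM holds the only true number so far. Compound 3 `N#Cc1ccc(/C=C/S(=O)(=O)Cc2ccc(Nc3ncnc4ccccc34)cc2)cc1` differs from it as follows: cyano in place of fluoro on an aromatic carbon. This is cyano in place of fluoro on an aromatic carbon, para to a large group.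

Within the data shown here, one measured step bears on this change, at the same place on the ring: an at least 7.6-fold lower number from compound 1 to compound 2 (0.88 log units; beyond the scatter). That step lies beyond the scatter, and its size rests on (the limit of > 100000 nM in this assay, at which 1 of the 2 values shown sits). It replaces hydrogen rather than fluoro and gives no direction for the new swap. No step beyond the scatter is therefore expected in this assay, though a wide range is kept. The expected step is a 1.3-fold lower number from compound 2 to compound 3 (0.11 log units; within the scatter). For compound 3 the estimated value is 10000 nM, with an expected range from 3000 nM to 35000 nM.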

Compound 3, concentration for 50% growth inhibition: > 100000 nM
Compound 3 was reported as a limit (the forecaster's own chance of this, stated with the estimate: 10%); middle value at least 10-fold (1.00 log units) from the limit.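

In this assay, the change from 4-fluorophenyl to 4-cyanophenyl gives an at least 7.6-fold higher number from compound 2 to compound 3 (0.88 log units; beyond the scatter), so the lower number that fluoro brought at this place, para to a large group, does not carry over to cyano. Fluoro is now the only one of the three groups shown at this place that gives a true number, which makes this position sensitive to the group it carries rather than open to any replacement of hydrogen. The step between the hydrogen of compound 1 and the cyano of compound 3 cannot be read: the limit of > 100000 nM in this assay, at which 2 of the 3 values shown sit.

Still open, going by these compounds, is whether the read-out of compound 2 is particular to fluoro or is shared by groups such as chloro, methyl or methoxy at the same place. With a single true number in the series, no trend across groups at this position can yet be stated.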